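Swapping methyl for tert-butyl on the amide aniline ring

The source may hold more compounds than are shown below. What is called first, only, known or untested is meant among the compounds shown, and "the series" means these compounds.

Measured compounds:
compound 1 `Cc1nc(NC(=O)c2cc(F)cc(C#N)c2)sc1C`: 594 nM
compound 2 `N#Cc1cc(F)cc(C(=O)Nc2ccccc2F)c1`: > 30000 nM
compound 3 `Cc1cccc(NC(=O)c2cc(F)cc(C#N)c2)c1`: 122 nM

In an in vitro functional assay on HEK293-A cells for antagonist activity at metabotropic glutamate receptor 5 (Rattus norvegicus), read by calcium flux (a higher number here means a weaker inhibitor, a lower number a stronger inhibitor), compound 3 gives 122 nM, the lowest of the two numbers obtained. Compound 1, in this assay, gives 594 nM, a higher number and a gap beyond the scatter. Compound 2 reaches only the limit of this assay, > 30000 nM, which is not a number; (the limit of > 30000 nM in this assay, at which 1 of the 3 values shown sits).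

Compound 4 `CC(C)(C)c1cccc(NC(=O)c2cc(F)cc(C#N)c2)c1` differs from compound 3 by one change: tert-butyl in place of methyl on an aromatic carbon. For the measured compounds named here, no measured pair shows a step of this kind, so the effect of a larger alkyl group here is untested. A modest weakening is expected, with a step of a 3.3-fold higher number from compound 3 to compound 4 (0.52 log units; beyond the scatter) that is itself estimated to sit near the edge of the scatter. Compound 4 is estimated at 400 nM, within 100 nM to 2000 nM.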

Compound 4, half-maximal inhibitory concentration: > 30000 nM
Compound 4: only a limit was reported (the forecaster's own chance of this, stated with the estimate: 5%); middle value at least 75-fold (1.87 log units) from the limit.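

For the compounds shown here, this is the first step measured at this spot on the aromatic ring, and it shows that activity depends strongly on which alkyl group sits there: tert-butyl in place of methyl gives an at least 240-fold higher number from compound 3 to compound 4 (2.39 log units; beyond the scatter). Compound 4 gives > 30000 nM, which is a limit of the assay and not a number. Methyl is therefore accepted here in this assay, whereas tert-butyl is not.

As far as these compounds go, with only these two groups compared at this position, it remains open whether ethyl or isopropyl would keep the activity. From the compounds shown here alone, whether an amine or a methoxy group would be accepted here is also open.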